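A few compounds are considered here, and "the series" means these few. Any claim that something is new, unique, unknown or untested is made for them only; others in the source may bear on it.

Working notes on the series. Three compounds on the shared core have been run in an assay on isolated protein for inhibition of protein kinase C delta type (Homo sapiens), read by TR-FRET, with a stated time of 2 h; on this read-out higher numbers stand for weaker inhibition and lower numbers for stronger inhibition. Compound 1 `N#Cc1cnc(NCc2cnccc2C(F)(F)F)cc1N[C@H]1CC[C@@H](O)CC1` gives 4500 nM in this assay. Compound 2 `N#Cc1cnc(NCc2ccccc2C(F)(F)F)cc1N[C@H]1CC[C@H](O)CC1` gives > 10000 nM in this assay, which is a limit of the assay and not a number. Compound 3 `N#Cc1cnc(NCc2cnccc2C(F)(F)F)cc1NCCC1CCOCC1` gives > 10000 nM in this assay, again a limit and not a number. Among the measured compounds shown here, the one single-point step measured so far, an at least 2.2-fold higher number from compound 1 to compound 3 (0.34 log units; beyond the scatter), replaces 4-hydroxycyclohexyl with 2-(oxan-4-yl)ethyl on a nitrogen on an aromatic ring and weakens inhibition; its true size is hidden because the limit of > 10000 nM in this assay, at which 2 of the 3 values shown sit, caps the read-out.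

Compound 2 thus stands at the weak end of the numbers shown, with only a limit known. Compound 4 `N#Cc1cnc(NCc2ccccc2C(F)(F)F)cc1N[C@H]1C[C@H](C(N)=O)C1` differs from it by 3-carbamoylcyclobutyl in place of 4-hydroxycyclohexyl on a nitrogen on an aromatic ring. For the measured compounds named here, no measured step covers this exchange; the only step on the same nitrogen, an at least 2.2-fold higher number from compound 1 to compound 3 (0.34 log units; beyond the scatter), went toward weaker inhibition. With compound 2 already at a limit, the step that the limit leaves unreadable from compound 2 to compound 4 is expected to stay near or beyond the scatter in either direction, and compound 4 is estimated at 15000 nM in this assay, within 4000 nM to 50000 nM.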

Compound 4, half-maximal inhibitory concentration: > 10000 nM
Compound 4 was reported as a limit; the forecaster's own chance of this, stated with the estimate: 60%; the middle value does not contradict the limit.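

No new step can be read from compound 2 to compound 4, since both results are limits and not numbers: the limit of > 10000 nM in this assay, at which 3 of the 4 values shown sit.

The compounds shown leave open whether 3-carbamoylcyclobutyl or 4-hydroxycyclohexyl on a nitrogen on an aromatic ring gives stronger inhibition.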